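This account rests on a few compounds, and the source may have more. Where it says the series, first, only, none or still open, it means among the compounds named here.

Measured compounds:
- Compound 1, `Cn1c(SCC(=O)N2CCC[C@H]2C(=O)Nc2ccccc2-n2cccc2)nc2ccccc21`, gives 9 nM in an assay on CHO cells for displacement of a labelled ligand from Orexin/Hypocretin receptor type 1 (Homo sapiens); a lower number here means a stronger inhibitor, a higher number a weaker inhibitor.
- Compound 2, `COc1ccccc1-c1ccccc1NC(=O)[C@@H]1CCCN1C(=O)CCc1nc2ccccc2[nH]1`, gives 86 nM in this assay.

Of the two numbers, compound 1 has the lower one, and the gap to compound 2 lies beyond the usual scatter of the method. Among the measured compounds shown here, no single-change step between these two has been worked out, so only their two values can be compared.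

Compound 3, `O=C(Nc1ccccc1-n1cccc1)[C@@H]1CCCN1C(=O)CSc1nc2ccccc2s1`, has not yet been measured. It differs from compound 1 in one place: 1,3-benzothiazol-2-yl in place of 1-methyl-1H-benzimidazol-2-yl on a sulfur. The rest of the shared core, with its proline amide and the aryl bearing the pyrrole, is untouched.

For the measured compounds named here, no measured pair shows what this exchange of one bicyclic ring for another does. Both groups count two hydrogen-bond acceptors and no donor, so the expectation is that the step of a 1.7-fold higher number from compound 1 to compound 3 (0.22 log units; within the scatter) is small, with no clear direction beyond the scatter. Compound 3 is therefore estimated at 15 nM, within a range from 4 nM to 60 nM.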

Compound 3, inhibition constant: 39 nM
For compound 3 the middle estimate is 2.6-fold (0.41 log units) below the measured one; the measured number falls inside the stated range.
By their numbers in this assay, from the lowest: compound 1; then compound 3; then compound 2.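

In this assay, among the compounds shown here, the exchange of 1-methyl-1H-benzimidazol-2-yl for 1,3-benzothiazol-2-yl on a sulfur gives a 4.3-fold higher number from compound 1 to compound 3 (0.64 log units; beyond the scatter) and is the first single-place change that can be read. This position therefore responds to the choice of bicyclic ring, even though both groups have the same counts of hydrogen-bond donors and acceptors and the same kinds of ring. Those counts alone thus do not settle the value here, and no measurement at hand explains the size or direction of this step.

The exchange removes the methyl group and replaces a ring nitrogen with sulfur at once, so the compounds shown cannot separate these two changes. Going by these compounds, it also remains open how other groups at this place would behave, such as 1,3-benzoxazol-2-yl or 1-ethyl-1H-benzimidazol-2-yl.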